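From Chlorophenyl to Methyl on an Ether Side Chain

This account rests on a few compounds, and the source may have more. Where it says the series, first, only, none or still open, it means among the compounds named here.

Of the compounds shown here, two sharing one core have been measured. Compound 1 `CCCCCOCNc1n[n+]([O-])c2ccccc2[n+]1[O-]` was tested in a functional assay on KB cells (Homo sapiens) for cytotoxicity, read by MTT assay, with a stated time of 72 h (on this read-out lower numbers stand for stronger inhibition and higher numbers for weaker inhibition), where compound 1 gives 39500 nM. Compound 2 `[O-][n+]1nc(NCOCc2ccc(Cl)cc2)[n+]([O-])c2ccccc21`, which differs from compound 1 only in having 4-chlorophenyl in place of butyl on a saturated chain carbon bound to an oxygen on a saturated carbon, was tested in the same way; in this assay compound 2 gives 8260 nM. That single step was a 4.8-fold lower number from compound 1 to compound 2 (0.68 log units; beyond the scatter). Among the compounds with values here, compound 2 therefore has the lower of the two numbers recorded, with compound 1 its only neighbour.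

Compound 3 `CCOCNc1n[n+]([O-])c2ccccc2[n+]1[O-]` is the next case. It differs from compound 2 as follows: methyl in place of 4-chlorophenyl on a saturated chain carbon bound to an oxygen on a saturated carbon. Within the data shown here, only one measured step bears on this change, and it runs the other way: when 4-chlorophenyl entered for butyl the number fell modestly. Taking away that aromatic group, and leaving a methyl even shorter than the butyl of compound 1, the number is expected to rise back at least to the level of compound 1, a 5.4-fold higher number from compound 2 to compound 3 (0.74 log units; beyond the scatter). The estimate for compound 3 in this assay is 45000 nM, within a range from 15000 nM to 140000 nM.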

Compound 3, half-maximal inhibitory concentration: 22500 nM
Compound 3: middle estimate off by 2.0-fold (0.30 log units), on the high side; low and high end bracket the measured number.
By their numbers in this assay, from the lowest: compound 2; then compounds 3 and 1 (each within the scatter of the next).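

The step from compound 2 to compound 3 in this assay, a 2.7-fold higher number from compound 2 to compound 3 (0.44 log units; beyond the scatter), shows that the 4-chlorophenyl group matters at this place from a second side: compound 2 now stands beyond the scatter from two compounds with saturated chains, not one. The comparison of the two saturated chains adds something the earlier pair could not show, since hydrogen in place of propyl on a saturated chain carbon, two bonds along the chain from an oxygen on a saturated carbon, gives a 1.8-fold lower number from compound 1 to compound 3 (0.24 log units; within the scatter), which lies within the scatter, so these two chain lengths cannot be told apart on this read-out. Among the three compounds, then, the separation follows the presence of the aromatic ring rather than the length of the saturated chain, and no measurement is at hand that accounts for it.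

As far as these compounds go, what remains open is whether the ring alone or its chlorine carries the step, which a plain phenyl or a 4-fluorophenyl at this place would help to settle. Also open, from the compounds shown here alone, is how a much longer chain, or a chain ending in an amine or a carboxylic acid, would read here.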